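Swapping the amine substituents on a fused pyrimidine core

A few compounds are considered here, and "the series" means these few. Any claim that something is new, unique, unknown or untested is made for them only; others in the source may bear on it.

Compound 1: `CCCN(CC1CC1)c1nc(C)nc2c1c(C)c(C)n2-c1c(C)cc(C)cc1C`, 2.3 nM
Compound 2: `CCN(CCCCF)c1nc(C)nc2c1c(C)c(C)n2-c1c(C)cc(C)cc1C`, 3.5 nM
Compound 3: `CCCN(CCCCF)c1nc(C)nc2c1c(C)c(C)n2-c1c(C)cc(C)cc1C`, 0.91 nM

All three compounds were tested in an assay on cerebellum with corticotropin-releasing factor receptor 1 (Rattus norvegicus) as the target; on this read-out higher numbers stand for weaker inhibition and lower numbers for stronger inhibition. Compound 3 gives the lowest number of the three: compound 1 stands nearest to it, and the step of a 2.5-fold lower number from compound 1 to compound 3 (0.40 log units; beyond the scatter) lies beyond the scatter, while the step of a 3.8-fold lower number from compound 2 to compound 3 (0.59 log units; beyond the scatter) is larger still. The step of a 1.5-fold higher number from compound 1 to compound 2 (0.18 log units; within the scatter) falls within the scatter.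

Compound 4, `Cc1cc(C)c(-n2c(C)c(C)c3c(N(CCCF)CC4CC4)nc(C)nc32)c(C)c1`, is not yet measured. It differs from compound 3 by (cyclopropylmethyl)(3-fluoropropyl)amino in place of (4-fluorobutyl)(propyl)amino on an aromatic carbon. For the measured compounds named here, two measured steps bear on this change. The step of a 2.5-fold lower number from compound 1 to compound 3 (0.40 log units; beyond the scatter) shows that a fluorinated chain in place of cyclopropyl lowered the number modestly, and the step of a 3.8-fold lower number from compound 2 to compound 3 (0.59 log units; beyond the scatter) shows that a longer chain also lowered it. Compound 4 keeps one fluorinated chain but reintroduces the cyclopropylmethyl group of compound 1, so a number between those of compound 1 and compound 3 is expected, a step of a 1.6-fold higher number from compound 3 to compound 4 (0.22 log units; within the scatter) of small size. The estimate for compound 4 in this assay is 1.5 nM, with a range from 0.5 nM to 4.5 nM.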

Compound 4, inhibition constant: 30 nM
The estimate for compound 4 lay 20-fold (1.30 log units) below the measured number; the measured number lies above the stated range.
By their numbers in this assay, from the lowest: compound 3; then compounds 1 and 2 (each within the scatter of the next); then compound 4.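

In this assay, for the compounds shown here, this aromatic carbon proved far less tolerant of a change in its amino group than the earlier compounds suggested: a 33-fold higher number from compound 3 to compound 4 (1.52 log units; beyond the scatter) arises although both groups have 9 heavy atoms, and the (cyclopropylmethyl)(3-fluoropropyl)amino group also compares poorly with the ethyl(4-fluorobutyl)amino group, with an 8.6-fold higher number from compound 2 to compound 4 (0.93 log units; beyond the scatter). Fluoro on the propyl chain, with cyclopropylmethyl kept, gives a 13-fold higher number from compound 1 to compound 4 (1.12 log units; beyond the scatter), so a fluorinated chain does not lower the number in every setting, and the 4-fluorobutyl change goes the other way, with a 2.5-fold lower number from compound 1 to compound 3 (0.40 log units; beyond the scatter). No measurement shown here accounts for the rise.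

The compounds shown leave open whether the 3-fluoropropyl chain raises the number by itself or only when paired with cyclopropylmethyl. A (3-fluoropropyl)(propyl)amino group at this position could separate those two readings.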